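Pyridin-3-yl in Place of sec-Butyl on an Amide Nitrogen

The source may hold more compounds than are shown below. What is called first, only, known or untested is meant among the compounds shown, and "the series" means these compounds.

Measured compounds:
Compound 1 `CC(=O)Nc1ccc2[nH]c(=O)n(O)c(=O)c2c1`: 87000 nM
Compound 2 `O=C(NCCO)c1nc(-c2cccs2)[nH]c(=O)c1O`: > 100000 nM (a limit of the assay)
Compound 3 `CCC(C)NC(=O)c1nc(-c2cccs2)[nH]c(=O)c1O`: > 100000 nM (a limit of the assay)

All three were tested in an assay on isolated protein for inhibition of deoxyribonuclease-1 (Homo sapiens); on this read-out higher numbers stand for weaker inhibition and lower numbers for stronger inhibition. Compound 1 gives 87000 nM. Compound 2 reaches only > 100000 nM, which is a limit of the assay and not a number. Compound 3 likewise reaches only > 100000 nM, again a limit of the assay. Compound 3 therefore stands at the edge of what this assay can read, a position shared by two of the three values shown (the limit of > 100000 nM in this assay, at which 2 of the 3 values shown sit). Among the compounds with values here, the single measured step, a step that the two limits leave unreadable from compound 2 to compound 3, is hidden between two limits and its size cannot be read.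

The next compound, compound 4 `O=C(Nc1cccnc1)c1nc(-c2cccs2)[nH]c(=O)c1O`, differs from compound 3 by pyridin-3-yl in place of sec-butyl on an amide-type nitrogen. Within the data shown here, no measured step brings an aromatic ring onto this amide nitrogen, so no step informs the change directly. Compound 3 sits at the limit, and compound 4 is expected to stay close to it. The expected step is a number no higher from compound 3 to compound 4 (the limit leaves the size open), nothing beyond the scatter. For compound 4 the estimate in this assay is 100000 nM, with a range from 30000 nM to 300000 nM.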

Compound 4, half-maximal inhibitory concentration: > 100000 nM
Compound 4 gave a limit, no number; the forecaster's own chance of this, stated with the estimate: 65%; the middle value sits exactly at the limit.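

Compound 4 also gives only a limit of the assay and not a number, so no step can be read among compound 2, compound 3 and compound 4: the limit of > 100000 nM in this assay, at which 3 of the 4 values shown sit. The compounds shown leave open how far past that limit these three lie in this assay.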